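Chain Extension on a Chloro Analogue Against HDAC6

The source may report more compounds than this note shows. Statements on the series, on what has been measured and on what is new or still open speak of the compounds shown alone.

Measured compounds:
Compound 1, `O=C(CCCCCn1cc(Nc2ncc3ccn(Cc4cccc(F)c4)c3n2)cn1)NO`: 13.7 nM
Compound 2, `O=C(CCCCCCn1cc(Nc2ncc3ccn(Cc4cccc(F)c4)c3n2)cn1)NO`: 14.7 nM
Compound 3, `O=C(CCCCCn1cc(Nc2ncc3ccn(Cc4cccc(Cl)c4)c3n2)cn1)NO`: 34.4 nM

All three numbers come from an assay on isolated protein for inhibition of protein deacetylase HDAC6 (Homo sapiens), with a stated time of 60 min; on this read-out lower numbers stand for stronger inhibition and higher numbers for weaker inhibition. Compound 1 and compound 2 differ only by the change ((hydroxycarbamoyl)methyl in place of hydroxycarbamoyl on a saturated chain carbon, five bonds along the chain from an aromatic nitrogen), and this step reads a 1.1-fold higher number from compound 1 to compound 2 (0.03 log units; within the scatter), so the two numbers are not distinguished from one another. Compound 3 carries a different core, differing from compound 1 by chloro in place of fluoro on an aromatic carbon, and that step reads a 2.5-fold higher number from compound 1 to compound 3 (0.40 log units; beyond the scatter), a modest shift that leaves compound 3 with the highest number of the three.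

Compound 4, `O=C(CCCCCCn1cc(Nc2ncc3ccn(Cc4cccc(Cl)c4)c3n2)cn1)NO`, has not yet been measured in this assay. Among the measured compounds shown here, it stands to compound 3 exactly as compound 2 stands to compound 1: the change (hydroxycarbamoyl)methyl in place of hydroxycarbamoyl on a saturated chain carbon, five bonds along the chain from an aromatic nitrogen is the same as the one made from compound 1 to compound 2, with the same place given for both. Only these two occurrences of the change exist among the compounds shown, and only one has been measured, so the expectation for compound 4 rests on a single precedent.

On that basis compound 4 is expected to show a step of a 1.1-fold higher number from compound 3 to compound 4 (0.03 log units; within the scatter), close to the flat step a 1.1-fold higher number from compound 1 to compound 2 (0.03 log units; within the scatter) seen on the fluoro core. Compound 4 is therefore estimated at 37 nM in this assay, with a plausible range from 18 nM to 75 nM.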

Compound 4, half-maximal inhibitory concentration: 36.8 nM
Compound 4: middle estimate off by 1.0-fold (0.00 log units), on the high side; the measured number falls inside the stated range.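

In this assay, putting (hydroxycarbamoyl)methyl in place of hydroxycarbamoyl on the chloro-bearing core gives a 1.1-fold higher number from compound 3 to compound 4 (0.03 log units; within the scatter), and this step agrees with the one seen on the fluoro-bearing core: the same change on two cores in this assay, a 1.1-fold higher number (0.03 log units; within the scatter) from compound 1 to compound 2 and a 1.1-fold higher number (0.03 log units; within the scatter) from compound 3 to compound 4, 1.0-fold (0.00 log units) apart, within the scatter of two such steps. Read on the longer chain, chloro in place of fluoro gives a 2.5-fold higher number from compound 2 to compound 4 (0.40 log units; beyond the scatter), and this step likewise agrees with its earlier counterpart: the same change on two cores in this assay, a 2.5-fold higher number (0.40 log units; beyond the scatter) from compound 1 to compound 3 and a 2.5-fold higher number (0.40 log units; beyond the scatter) from compound 2 to compound 4, 1.0-fold (0.00 log units) apart, within the scatter of two such steps. Each change therefore reads the same on both partners among these four compounds, but this is one pair of closely related cores in a single assay, so it does not show that either step would carry over to other cores, and the flat chain step shows only that no difference was resolved here.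

The compounds shown leave open whether a shorter chain or a still longer one would stay as flat on either core, and whether a bromo or a methyl group in place of chloro would extend the step seen from fluoro to chloro. They also leave open how a carboxylic acid in place of hydroxycarbamoyl would read on these cores.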